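Trading an Aromatic Sulfonyl Group for Butyl

The source may hold more compounds than are shown below. What is called first, only, known or untested is meant among the compounds shown, and "the series" means these compounds.

In a functional assay on MDA-MB-231 cells (Homo sapiens) for antiproliferative activity, read by sulforhodamine B assay, with a stated time of 72 h (a higher number here means a weaker inhibitor, a lower number a stronger inhibitor), compound 1 (`CCCCS(=O)(=O)Nc1cc(-c2ccc3ncnc(NCc4ccncc4)c3c2)cnc1OC`) gives 4320 nM and compound 2 (`COc1ncc(-c2ccc3ncnc(NCCCN(C)C)c3c2)cc1NS(=O)(=O)c1ccc(F)cc1F`) gives 1540 nM as the lower of the two numbers, a gap beyond the usual scatter. Compound 3 (`CCCCS(=O)(=O)Nc1cc(-c2ccc3ncnc(NCCCN(C)C)c3c2)cnc1OC`) differs from compound 2 in one place (butyl in place of 2,4-difluorophenyl on a sulfonyl sulfur): butyl in place of 2,4-difluorophenyl on a sulfonyl sulfur. Among the compounds with values here, no measured pair shows this change alone, so the forecast is loose. A modest rise in the number, meaning somewhat weaker inhibition, is expected (a 1.6-fold higher number from compound 2 to compound 3 (0.21 log units; within the scatter)). Compound 3 is expected to give about 2500 nM (estimated range 800 nM to 7000 nM).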

Compound 3, half-maximal inhibitory concentration: 880 nM
Compound 3: the middle estimate sits 2.8-fold (0.45 log units) above what was measured, within the range that was stated.
By their numbers in this assay, from the lowest: compounds 3 and 2 (each within the scatter of the next); then compound 1.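

On the sulfonyl sulfur, an open-chain butyl does as well as the ring-bearing 2,4-difluorophenyl, so the aromatic ring is not needed at this position in this pair (a 1.8-fold lower number from compound 2 to compound 3 (0.24 log units; within the scatter)). With butyl held in place, the other side of the molecule does matter: 2-(dimethylamino)ethyl in place of pyridin-4-yl gives a clear gain (a 4.9-fold lower number from compound 1 to compound 3 (0.69 log units; beyond the scatter)). No measurement here explains either result.

Still open, as far as these compounds go, is how methyl or unsubstituted phenyl on the sulfonyl sulfur compares with butyl. Also open, from the compounds shown here alone, is whether morpholine in place of the dimethylamino group holds the gain.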